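Hydrazone variation on a shared triazolopyrimidine core

This account rests on a few compounds, and the source may have more. Where it says the series, first, only, none or still open, it means among the compounds named here.

Working notes on the series, measured in a functional assay on MCF7 cells (Homo sapiens) for antiproliferative activity, read by MTT assay, with a stated time of 72 h; a higher number here means a weaker inhibitor, a lower number a stronger inhibitor:

compound 1, `CCCSc1nc(N/N=C(\C)c2ccc(O)cc2)c2nnn(Cc3ccccc3)c2n1`, compound 1 gives 21600 nM
compound 2, `CCCSc1nc(N/N=C/c2c[nH]c3ccccc23)c2nnn(Cc3ccccc3)c2n1`, compound 2 gives 9010 nM

Compound 2 holds the lower of the two numbers in this assay; compound 1 sits at a higher number, and the gap between compound 1 and compound 2 lies beyond the usual scatter. Going by the values given here, the two compounds differ in more than one place, so no single step can be drawn between them.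

Compound 3 is `CCCSc1nc(N/N=C/c2ccccc2)c2nnn(Cc3ccccc3)c2n1`, not yet measured. It differs from compound 2 as follows: phenyl in place of 1H-indol-3-yl on a carbon with a double bond to nitrogen.

Among the compounds with values here, no step between measured compounds covers this change. Loss of the indole donor and the second ring is expected to cost potency, with a step of a 2.2-fold higher number from compound 2 to compound 3 (0.35 log units; beyond the scatter) that should reach beyond the scatter. Compound 3 is thus estimated at 20000 nM, with a range from 8000 nM to 50000 nM.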

Compound 3, half-maximal inhibitory concentration: > 64000 nM
Compound 3 ended at the assay's limit; the forecaster's own chance of this, stated with the estimate: 10%; middle value at least 3.2-fold (0.50 log units) away from the limit.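

Compound 3 stands at a limit of this assay, not at a number: the limit of > 64000 nM in this assay, at which 1 of the 3 values shown sits.

On the carbon with a double bond to nitrogen, phenyl in place of 1H-indol-3-yl gives an at least 7.1-fold higher number from compound 2 to compound 3 (0.85 log units; beyond the scatter), the first single-place change read at this site, and it shows that the activity of compound 2 in this assay depends on the group placed there. On the nitrogen on an aromatic ring, the group of 8 heavy atoms in place of the group of 10 heavy atoms gives an at least 2.9-fold higher number from compound 1 to compound 3 (0.47 log units; beyond the scatter), so both measured groups at this site stand ahead of the group in compound 3.

The compounds shown do not separate the hydrogen-bond donor from the five-membered aromatic ring, which leave together with 1H-indol-3-yl; a naphthyl or a pyrrolyl group on that carbon would part the two. Also open, on these data alone, is how the series responds at the other sites of the shared core, for instance to an amine in place of the propyl chain.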